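The source may hold more compounds than are shown below. What is called first, only, known or untested is meant among the compounds shown, and "the series" means these compounds.

In a functional assay on PC-3 cells (Homo sapiens) for cytotoxicity, read by MTT assay, with a stated time of 72 h (on this read-out lower numbers stand for stronger inhibition and higher numbers for weaker inhibition), compound 1 (`CC1=C(/C=C/C(=O)/C=C/c2cccc(C(F)(F)F)c2)C(C)(C)CCC1`) gives 7700 nM. Compound 2 (`CC1=C(/C=C/C(=O)/C=C/c2cc(C(F)(F)F)cc(C(F)(F)F)c2)C(C)(C)CCC1`) gives 7200 nM, within the scatter of compound 1, while compound 3 (`CC1=C(/C=C/C(=O)/C=C/c2cccc(C)c2)C(C)(C)CCC1`) gives 35000 nM, a clearly weaker result. Compound 4 (`CC1=C(/C=C/C(=O)/C=C/c2cccc(C(F)(F)F)c2)C(C)(C)CCC1O`) is still unmeasured and differs from compound 1 by hydroxy in place of hydrogen on a saturated ring carbon. The two measured steps, a 1.1-fold lower number from compound 1 to compound 2 (0.03 log units; within the scatter) and a 4.5-fold higher number from compound 1 to compound 3 (0.66 log units; beyond the scatter), both alter a group on an aromatic carbon, so neither tests this site directly. Only a modest step is therefore expected, leaning towards a higher number, though that direction is uncertain. The expected step is a 1.6-fold higher number from compound 1 to compound 4 (0.19 log units; within the scatter). For compound 4 the estimated value is 12000 nM, with an expected range of 4000 nM to 35000 nM.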

Compound 4, half-maximal inhibitory concentration: 3500 nM
The estimate for compound 4 lay 3.4-fold (0.54 log units) above the measured number, outside the stated range (below it).
By their numbers in this assay, from the lowest: compound 4; then compounds 2 and 1 (each within the scatter of the next); then compound 3.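

Hydroxy in place of hydrogen on this saturated ring carbon gives a 2.2-fold lower number from compound 1 to compound 4 (0.34 log units; beyond the scatter) in this assay, a modest step beyond the scatter. Among the compounds shown here, the earlier steps changed only groups on an aromatic carbon, so this is the first sign that the six-membered non-aromatic ring can also shift the number, here towards stronger inhibition. No measurement shown explains this gain. On these data alone, whether a methoxy group or an amine on this carbon would act like hydroxy remains open. So does whether hydroxy here would give a similar step alongside the aromatic groups of compound 2 or compound 3.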